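The compounds below may be only part of what the source reports. "The series", "measured", "known", "first", "only" and "open" are said of these compounds alone.

The measured compounds in a functional assay on A549 cells (Homo sapiens) for antiproliferative activity, read by MTT assay, with a stated time of 72 h; a lower number here means a stronger inhibitor, a higher number a weaker inhibitor:
compound 1, `CC(C)OC1=C(C(=O)c2ccccc2)C(c2ccc(Br)cc2)N(CCCn2ccnc2)C1=O`, gives 8720 nM;
compound 2, `O=C(C1=C(OC2CCCCC2)C(=O)N(CCCn2ccnc2)C1c1ccc(Br)cc1)c1ccccc1`, gives 31200 nM;
compound 3, `CCOc1ccc(NC2=C(C(=O)c3ccccc3)C(c3ccc(Br)cc3)N(CCCn3ccnc3)C2=O)cc1`, gives 20200 nM.

Compound 3 stands apart from compound 1 by a 2.3-fold higher number from compound 1 to compound 3 (0.36 log units; beyond the scatter), while against compound 2 the gap is only a 1.5-fold lower number from compound 2 to compound 3 (0.19 log units; within the scatter), within the scatter. Compound 4, `O=C(C1=C(Nc2ccc(Br)cc2)C(=O)N(CCCn2ccnc2)C1c1ccc(Br)cc1)c1ccccc1`, differs from compound 3 by bromo in place of ethoxy on an aromatic carbon. Within the data shown here, no measured step touches that aromatic carbon; the three steps seen all concern the group on the double-bonded ring carbon, and the largest of them, a 3.6-fold higher number from compound 1 to compound 2 (0.55 log units; beyond the scatter), is itself modest. With nothing in the data pointing either way, the expected step of a 1.0-fold lower number from compound 3 to compound 4 (0.00 log units; within the scatter) is none beyond the scatter. Compound 4 is therefore estimated at 20000 nM, within a range from 7000 nM to 55000 nM.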

Compound 4, half-maximal inhibitory concentration: 22200 nM
Compound 4: middle estimate off by 1.1-fold (0.05 log units), on the low side; low and high end bracket the measured number.
By their numbers in this assay, from the lowest: compound 1; then compounds 3, 4 and 2 (each within the scatter of the next).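

Bromo in place of ethoxy on the aromatic carbon, the first change seen at this place, gives a 1.1-fold higher number from compound 3 to compound 4 (0.04 log units; within the scatter), so the two groups cannot be told apart here. Against the oxygen-linked groups on the double-bonded ring carbon, (4-bromophenyl)amino gives a 1.4-fold lower number from compound 2 to compound 4 (0.15 log units; within the scatter) and a 2.5-fold higher number from compound 1 to compound 4 (0.41 log units; beyond the scatter), and only the second of these steps lies beyond the scatter. No evidence is available that bears on this result.

As far as these compounds go, whether the aromatic carbon stays this tolerant with an amine or a carboxylic acid there remains open.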